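Methoxy for methyl on the aryl ring of compound 1

This account rests on a few compounds, and the source may have more. Where it says the series, first, only, none or still open, it means among the compounds named here.

Three close relatives of one core have been tested in a physicochemical assay for solubility, in phosphate buffer, measured as kinetic solubility, at pH 7.4; a higher number here means a more soluble compound, a lower number a less soluble compound. Within the data shown here, compound 1 `Cc1ccc(C)c(-c2nc(CN3CCC(C(=O)NCCCN4C[C@H](C)C[C@H](C)C4)CC3)c(C)o2)c1` gives 56.1 ug/mL and is the only compound here with an actual number. Compound 2 `Cc1ccccc1-c1nc(CN2CCC(C(=O)NCCCN3CCC(C)(C)CC3)CC2)c(C)o1` reaches a limit of the assay, > 69 ug/mL, rather than a number. Compound 3 `Cc1ccccc1-c1nc(CN2CCC(C(=O)NCCCCN3C[C@H](C)C[C@H](C)C3)CC2)c(C)o1` likewise stops at a limit of the assay, > 71 ug/mL. Among the measured compounds shown here, the one step that could be read between measured compounds is a step that the two limits leave unreadable from compound 2 to compound 3, and with both ends at a limit it tells nothing of size.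

Compound 4 `COc1cccc(C)c1-c1nc(CN2CCC(C(=O)NCCCN3C[C@H](C)C[C@H](C)C3)CC2)c(C)o1` differs from compound 1 only on the aryl ring attached to the core: 2-methoxy-6-methylphenyl in place of 2,5-dimethylphenyl on an aromatic carbon. For the measured compounds named here, no measured step touches this ring, so nothing here shows how such a change moves solubility. The change is small in atom count and leaves the charged part untouched, and the expectation is therefore a step within the usual scatter, in no clear direction. Compound 4 is estimated at 60 ug/mL, with a likely range from 30 ug/mL to 120 ug/mL, a step of a 1.1-fold higher number from compound 1 to compound 4 (0.03 log units; within the scatter) from compound 1.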

Compound 4, solubility: > 73 ug/mL
Compound 4: a limit, no number; the forecaster's own chance of this, stated with the estimate: 35%; at least 1.2-fold (0.08 log units) between middle value and limit.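

Among these compounds, compound 4 gives the first readable step at this position of the shared core in this assay, and all earlier comparisons left this aryl ring untouched. Compound 4 stops at a limit of the assay and has no number: the limit of > 73 ug/mL in this assay, at which 1 of the 4 values shown sits. The step is an at least 1.3-fold higher number from compound 1 to compound 4 (0.11 log units; that floor lies within the scatter), so 2-methoxy-6-methylphenyl in place of 2,5-dimethylphenyl shows no loss of solubility, but the floor of this step is too small to prove a gain.

Going by these compounds, how far compound 4 lies beyond its limit stays open, and so does how much of the step belongs to the methoxy group and how much to the different placing of the methyl group. An aryl ring carrying a methoxy group alone, or an amine or a carboxylic acid instead, could help to separate these questions.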